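Halogen Gives Way to an Ester in a Cytotoxicity Series

A few compounds are considered here, and "the series" means these few. Any claim that something is new, unique, unknown or untested is made for them only; others in the source may bear on it.

The measured compounds:
Compound 1 `O=C(/C=C/c1ccc2c(c1)B(O)OC2)c1cccnc1` gives 76200 nM in a toxicity assay on WI-38 cells (Homo sapiens) for cytotoxicity, read by MTT assay, with a stated time of 48 h; a lower number here means a stronger inhibitor, a higher number a weaker inhibitor.
Compound 2 `O=C(/C=C/c1ccc2c(c1)B(O)OC2)c1ccc(Cl)cc1` gives 24700 nM in this assay.
Compound 3 `O=C(/C=C/c1ccc2c(c1)B(O)OC2)c1ccc(Br)cc1` gives 36700 nM in this assay.

Compound 2 holds the lowest number of the three, yet its nearest neighbour is not truly separated from it: a 1.5-fold higher number from compound 2 to compound 3 (0.17 log units; within the scatter). The other two steps are beyond the scatter: a 3.1-fold lower number from compound 1 to compound 2 (0.49 log units; beyond the scatter) and a 2.1-fold lower number from compound 1 to compound 3 (0.32 log units; beyond the scatter). In words, the six-membered aromatic ring of carbon only that carries a halogen gives a lower number than the pyridin-3-yl ring, while chloro and bromo cannot be told apart.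

The next compound, compound 4 `CCOC(=O)c1ccc(C(=O)/C=C/c2ccc3c(c2)B(O)OC3)cc1`, keeps the shared core and changes only the group on the aromatic carbon of that ring: ethoxycarbonyl in place of chloro on an aromatic carbon

Among the compounds with values here, no measured step replaces a halogen with an ethoxycarbonyl group, so the only guide is that the one compound bearing hydrogen-bond acceptors on this ring, compound 1, gave the highest number. The step therefore expected, with wide uncertainty, is a 1.7-fold higher number from compound 2 to compound 4 (0.23 log units; within the scatter). Compound 4 is estimated to give 42000 nM in this assay, within 15000 nM to 115000 nM.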

Compound 4, half-maximal inhibitory concentration: 47200 nM
Compound 4: the middle estimate sits 1.1-fold (0.05 log units) below what was measured, within the range that was stated.
By their numbers in this assay, from the lowest: compounds 2, 3, 4 and 1 (each within the scatter of the next, the first and the last beyond it).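

In this assay, putting the ethoxycarbonyl group, with its 5 heavy atoms and 2 hydrogen-bond acceptors, where a single chlorine atom stood gives a 1.9-fold higher number from compound 2 to compound 4 (0.28 log units; within the scatter), and the same exchange for bromo gives a 1.3-fold higher number from compound 3 to compound 4 (0.11 log units; within the scatter), so neither step separates the new compound from the halogen compounds. The earlier compounds shown here could only compare two single halogen atoms on this aromatic carbon, para to a large group, whereas compound 4 shows that a far larger group with hydrogen-bond acceptors can sit there without a change that stands out from the scatter. Nothing measured here offers an explanation for this result.

The compounds shown leave open whether a carboxylic acid or an amine on this same carbon would also stay within the scatter of compound 2, or would move the number clearly away from it. On these data alone, it also remains open how far this tolerance extends, for example whether an ester with a longer chain in place of the ethyl part would give a similar number.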